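Removing the hydroxy group from a prostacyclin receptor ligand

A few compounds are considered here, and "the series" means these few. Any claim that something is new, unique, unknown or untested is made for them only; others in the source may bear on it.

Measured compounds and their values:
- Compound 1, `CCCCCC(O)/C=C/CCC1CCCc2c(OCC(=O)O)cccc21`: 9600 nM
- Compound 2, `O=C(O)COc1cccc2c1CCC(C/C=C/C(O)Cc1ccccc1)C2`: 4900 nM
- Compound 3, `O=C(O)COc1cccc2c1CCC(C/C=C\CC(c1ccccc1)c1ccccc1)C2`: 3000 nM

Of the compounds shown here, three sharing one core have been tested in an assay for displacement of a labelled ligand from prostacyclin receptor (Homo sapiens); on this read-out higher numbers stand for weaker inhibition and lower numbers for stronger inhibition. Compound 1, `CCCCCC(O)/C=C/CCC1CCCc2c(OCC(=O)O)cccc21`, gives 9600 nM in this assay. Compound 2, `O=C(O)COc1cccc2c1CCC(C/C=C/C(O)Cc1ccccc1)C2`, gives 4900 nM, and compound 3, `O=C(O)COc1cccc2c1CCC(C/C=C\CC(c1ccccc1)c1ccccc1)C2`, gives 3000 nM. The number for compound 2 sits between those of compound 3 and compound 1, and both gaps fall within the usual scatter of the measurement, so none of the three can be set apart from the others.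

Compound 4, `O=C(O)COc1cccc2c1CCC(C/C=C/CCc1ccccc1)C2`, has not yet been measured. It differs from compound 2 in one place: hydrogen in place of hydroxy on a saturated chain carbon bound to a double-bonded chain carbon and a saturated chain carbon, which reads as hydrogen in place of hydroxy on a saturated chain carbon bound to a double-bonded chain carbon and a saturated chain carbon. Within the data shown here, no pair of measured compounds shows this change in isolation, and the three measured values lie within the scatter of one another, so no direction can be read from them.

The step from compound 2 to compound 4 in this assay is therefore expected to be a 1.0-fold higher number from compound 2 to compound 4 (0.01 log units; within the scatter), none beyond the scatter. Compound 4 is estimated at 5000 nM, with a range from 2000 nM to 13000 nM.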

Compound 4, half-maximal inhibitory concentration: 5300 nM
For compound 4 the middle estimate is 1.1-fold (0.03 log units) below the measured one; low and high end bracket the measured number.
By their numbers in this assay, from the lowest: compounds 3, 2, 4 and 1 (each within the scatter of the next, the first and the last beyond it).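

The earlier compounds shown here held no pair that isolated this position, but compound 2 and compound 4 now do. In this assay the change of hydroxy to hydrogen on a saturated chain carbon bound to a double-bonded chain carbon and a saturated chain carbon gives a 1.1-fold higher number from compound 2 to compound 4 (0.03 log units; within the scatter) and so leaves the two compounds indistinguishable, which means that here 1-hydroxy-2-phenylethyl and phenethyl cannot be told apart. With one hydrogen-bond donor and one hydrogen-bond acceptor gone and the reading still within the scatter, the hydroxy group is shown to be dispensable for a value of this level in this pair, although nothing available explains this result.

The compounds shown leave open whether an amine, a methoxy group or a fluorine on this same carbon would also read like hydroxy and hydrogen, or would instead stand apart from them. They also leave open whether hydrogen in place of hydroxy would give a similar step on the chain of compound 1, which differs from compound 2 in more than one place.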